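This account rests on a few compounds, and the source may have more. Where it says the series, first, only, none or still open, it means among the compounds named here.

In a functional assay on the whole organism (Abdomen, strain Swiss) for inhibition, with Mus musculus as the target, with stated times of 30 min, 10 min and 5 min, at a dose of 20 mg/kg by the oral route (a lower number here means a weaker effect, a higher number a stronger effect of the compound at the dose given), three compounds have been measured:

Compound 1, `CCC(=O)c1c(C)nn(CCCN2CCN(c3ccc(C)cc3)CC2)c(=O)c1N`, gives 40%.
Compound 2, `CC/C=C/c1c(C)nn(CCCN2CCN(c3ccc(C)cc3)CC2)c(=O)c1N`, gives 35%.
Compound 3, `Cc1c(C#N)c(-c2ccccc2)nn1CCCN1CCN(c2ccc(F)cc2)CC1`, gives 28%.

Of the three numbers, that of compound 3 is the lowest; its gap to compound 2 lies within the scatter, and only its gap to compound 1 lies beyond it. For the measured compounds named here, the one measured step, a number 5 percentage points lower from compound 1 to compound 2 (within the scatter), concerns the core shared by compound 1 and compound 2 and not the part of the molecule that changes here.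

Compound 4, `Cc1c(C#N)c(-c2ccccc2)nn1CCCN1CCN(c2cccc(Cl)c2)CC1`, has not yet been measured. It differs from compound 3 in one place: 3-chlorophenyl in place of 4-fluorophenyl on an amine nitrogen in a ring. Going by the values given here, no measured step touches the aryl group on the ring nitrogen, so there is nothing in the data that points in either direction. The step from compound 3 to compound 4 in this assay is therefore expected to be no change at the digits printed from compound 3 to compound 4 (within the scatter), which is no step beyond the scatter. For compound 4 the expected value is 28%, within a range from 15% to 42%.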

Compound 4, a percentage reported as inhibition, in the whole organism at one dose (the size of the read-out at that dose, not a potency): 0%
Compound 4: the middle estimate sits 28 percentage points above what was measured, and the stated range ends above it.
By their numbers in this assay, from the lowest: compound 4; then compounds 3, 2 and 1 (each within the scatter of the next, the first and the last beyond it).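

In this assay the exchange of 4-fluorophenyl for 3-chlorophenyl on the amine nitrogen in the ring gives a number 28 percentage points lower from compound 3 to compound 4 (beyond the scatter), the only step shown at this position, so the aryl group there is not a silent part of the molecule. The two groups have the same counts of heavy atoms, hydrogen-bond donors and hydrogen-bond acceptors, so these counts do not separate them. No measurement shown here bears on why the number changes.

The change swaps the halogen and its place on the phenyl at once, and the compounds shown cannot tell which of the two carries the step; a 4-chlorophenyl or a 3-fluorophenyl on the same nitrogen would separate them. From the compounds shown here alone, it also remains open whether the step would hold on the core of compound 1.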